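Swapping Acetyl for Tert-Butyl on the Shared Core

The source may hold more compounds than are shown below. What is called first, only, known or untested is meant among the compounds shown, and "the series" means these compounds.

Among the compounds with values here, compound 2 `CC(=O)c1ccc(-c2nc3cc([N+](=O)[O-])ccc3[nH]2)cc1` gives 9320 nM in a functional assay for antagonist activity at Neuropeptides B/W receptor type 1 (Homo sapiens), read by cAMP accumulation (a higher number here means a weaker inhibitor, a lower number a stronger inhibitor), the higher of the two numbers measured so far; compound 1 `O=[N+]([O-])c1ccc2[nH]c(-c3ccc(N4CCCC4)cc3)nc2c1` gives 1810 nM. Within the data shown here, the single measured step, a 5.1-fold higher number from compound 1 to compound 2 (0.71 log units; beyond the scatter), came from exchanging the group at the same aromatic carbon that is changed here. Compound 3 `CC(C)(C)c1ccc(-c2nc3cc([N+](=O)[O-])ccc3[nH]2)cc1` differs from compound 2 by tert-butyl in place of acetyl on an aromatic carbon. Among the measured compounds shown here, no measured step covers this exact exchange, so the expectation rests only loosely on a 5.1-fold higher number from compound 1 to compound 2 (0.71 log units; beyond the scatter). Compound 3 is expected to give about 4500 nM, somewhere between 1500 nM and 13000 nM. That corresponds to an expected step of a 2.1-fold lower number from compound 2 to compound 3 (0.32 log units; beyond the scatter).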

Compound 3, half-maximal inhibitory concentration: 3180 nM
Beside the measured number, compound 3's estimate is 1.4-fold (0.15 log units) above it, and the stated range covers the measured number.
By their numbers in this assay, from the lowest: compounds 1 and 3 (each within the scatter of the next); then compound 2.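

Tert-butyl at this aromatic carbon, para to a large group, gives a 2.9-fold lower number from compound 2 to compound 3 (0.47 log units; beyond the scatter) in this assay, so a group with no hydrogen-bond acceptor can stand here in place of acetyl without loss. Against the earlier pyrrolidin-1-yl, tert-butyl gives a 1.8-fold higher number from compound 1 to compound 3 (0.24 log units; within the scatter), so these two groups cannot be told apart in this assay, although only one of them contains nitrogen. Nothing at hand explains either step.

On these data alone, a carboxylic acid or a longer carbon chain at this carbon remains open. So does whether any group here can go clearly beyond compound 1 and compound 3.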